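A few compounds are considered here, and "the series" means these few. Any claim that something is new, unique, unknown or untested is made for them only; others in the source may bear on it.

Measured compounds:
- compound 1 `Fc1cc(Cl)ccc1N1CCN(Cc2ccn3c(CC4CC4)nnc3c2C(F)(F)F)CC1` — 7280 nM in a functional assay on HEK293 cells for agonist activity at metabotropic glutamate receptor 2 (Homo sapiens), read by a luciferase reporter and cAMP accumulation; on this read-out higher numbers stand for an effect only at larger amounts of compound and lower numbers for an effect already at smaller amounts
- compound 2 `Fc1ccc(N2CCN(Cc3cc(C(F)(F)F)cn4c(CC5CC5)nnc34)CC2)c(F)c1` — 136 nM in this assay

Compound 1 gives the highest number of the two; compound 2 gives a number far lower, and the gap is well beyond the scatter. Compound 2 differs from compound 1 in more than one place, so no single structural step can be read from the pair; it only shows the range this series covers.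

Compound 3 `Fc1ccc(N2CCN(Cc3ccn4c(CC5CC5)nnc4c3C(F)(F)F)CC2)c(Cl)c1` is not yet measured. It keeps the core of compound 1 and differs only on the aryl group: 2-chloro-4-fluorophenyl in place of 4-chloro-2-fluorophenyl on an amine nitrogen in a ring. Among the measured compounds shown here, no measured pair shows such a swap of the halogen positions on the aryl group, so the size of the step cannot be read from the numbers at hand. A modest shift toward a lower number is expected, probably within or close to the scatter: the step from compound 1 to compound 3 is estimated as a 2.4-fold lower number from compound 1 to compound 3 (0.39 log units; beyond the scatter). Compound 3 is expected to give about 3000 nM in this assay, within a range of 700 nM to 13000 nM.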

Compound 3, half-maximal effective concentration: 2350 nM
Beside the measured number, compound 3's estimate is 1.3-fold (0.11 log units) above it, and the stated range covers the measured number.
By their numbers in this assay, from the lowest: compound 2; then compound 3; then compound 1.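

Swapping the halogen positions on the aryl group, from 4-chloro-2-fluorophenyl to 2-chloro-4-fluorophenyl, gives in this assay a 3.1-fold lower number from compound 1 to compound 3 (0.49 log units; beyond the scatter) on an otherwise unchanged core. The group keeps the same heavy atoms, so this position on the ring amine nitrogen responds to how the two halogens are arranged, and not only to which halogens are present. No measurement at hand offers an explanation for the step.

The compounds shown leave open whether halogens are needed on this aryl group at all, which an unsubstituted phenyl, a methoxy group or a nitrile in place of the chlorine would address. From the compounds shown here alone, it also remains open whether the same swap gives a step of similar size on the core of compound 2.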